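The source may hold more compounds than are shown below. What is called first, only, known or untested is meant among the compounds shown, and "the series" means these compounds.

Compound 1 `FC(F)(F)Oc1ccc(Nc2cc(-n3ccnc3)ncn2)cc1`: in an ADME assay on BaF3 cells (Mus musculus) for cytotoxicity (on this read-out lower numbers stand for an effect already at smaller amounts and higher numbers for an effect only at larger amounts of compound), compound 1 gives > 10000 nM, which is a limit of the assay.
Compound 2 `NC(=O)c1ccc(-c2cc(Nc3ccc(OC(F)(F)F)cc3)ncn2)cc1`: in this assay compound 2 gives > 10000 nM, again a limit.
Compound 3 `NC(=O)c1ccccc1-c1cc(Nc2ccc(OC(F)(F)F)cc2)ncn1`: in this assay compound 3 gives > 10000 nM, also a limit.

Compound 3 thus stands at the limit, where (the limit of > 10000 nM in this assay, at which 3 of the 3 values shown sit). Compound 4 `FC(F)(F)Oc1ccc(Nc2cc(-c3ccnc4[nH]ccc34)ncn2)cc1` differs from it by a group of 9 heavy atoms (7 carbon, 2 nitrogen; one five-membered aromatic ring with 1 hetero atom, one six-membered aromatic ring with 1 hetero atom) in place of a group of 9 heavy atoms (7 carbon, 1 nitrogen, 1 oxygen; one six-membered aromatic ring of carbon only), on an aromatic carbon. The measured steps a step that the two limits leave unreadable from compound 1 to compound 2, a step that the two limits leave unreadable from compound 1 to compound 3 and a step that the two limits leave unreadable from compound 2 to compound 3 all run between limits, so none of them gives a readable size, and none concerns the group that enters in compound 4. Compound 4 is therefore expected to remain at the limit as well, with a number no higher from compound 3 to compound 4 (the limit leaves the size open) as the estimated step. For compound 4 the estimate is 10000 nM, in the range 4000 nM to 30000 nM.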

Compound 4, half-maximal effective concentration: 6850 nM
Compound 4: the middle estimate sits 1.5-fold (0.16 log units) above what was measured, and the stated range covers the measured number.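

Within the data shown here, at this position, on an aromatic carbon next to the ring nitrogen, the group entering in compound 4 gives the first readable number in this assay, whereas compound 1, compound 2 and compound 3 each stay at a limit: the limit of > 10000 nM in this assay, at which 3 of the 4 values shown sit. The record shows an at least 1.4-fold lower number from compound 3 to compound 4 (0.16 log units; that floor lies within the scatter), an at least 1.4-fold lower number from compound 2 to compound 4 (0.16 log units; that floor lies within the scatter) and an at least 1.4-fold lower number from compound 1 to compound 4 (0.16 log units; that floor lies within the scatter), so these floors establish no change beyond the scatter. The steps among the three earlier compounds cannot be read.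

As far as these compounds go, the true size of the steps to compound 4 remains open. So does whether a carboxylic acid or an amine at this position would also give a readable number.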